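The source may hold more compounds than are shown below. What is called first, only, known or untested is meant among the compounds shown, and "the series" means these compounds.

Measured in an assay on isolated protein for binding affinity to Oxytocin receptor (Homo sapiens); a higher number here means a weaker inhibitor, a lower number a stronger inhibitor:
compound 1 `CC(C)C[C@@H]1C(=O)N[C@H](C2Cc3ccccc3C2)C(=O)N1[C@@H](C(=O)NC(C)(C)C)c1ccoc1`: 12.6 nM
compound 2 `CC(C)C[C@@H]1C(=O)N[C@H](C2Cc3ccccc3C2)C(=O)N1[C@@H](C(=O)NC(C)C)c1ccco1`: 6.31 nM
compound 3 `CNC(=O)c1ccc([C@H](C(=O)NC(C)C)N2C(=O)[C@@H](C3Cc4ccccc4C3)NC(=O)[C@H]2CC(C)C)o1`: 39.8 nM

Compound 3 holds the highest number of the three, beyond the scatter from both compound 1 and compound 2. Within the data shown here, the only measured step that touches it is a 6.3-fold higher number from compound 2 to compound 3 (0.80 log units; beyond the scatter), a modest loss on adding the methylcarbamoyl. Compound 4 `CC(C)C[C@@H]1C(=O)N[C@H](C2Cc3ccccc3C2)C(=O)N1[C@@H](C(=O)NC(C)C)c1ccc(-c2ccccn2)s1` differs from compound 3 by a group of 11 heavy atoms (9 carbon, 1 nitrogen, 1 sulfur; one five-membered aromatic ring with 1 hetero atom, one six-membered aromatic ring with 1 hetero atom) in place of a group of 9 heavy atoms (6 carbon, 1 nitrogen, 2 oxygen; one five-membered aromatic ring with 1 hetero atom), on a saturated chain carbon bound to an amide-type nitrogen in a ring and a carbonyl carbon. The methylcarbamoyl leaves again, and on the evidence of a 6.3-fold higher number from compound 2 to compound 3 (0.80 log units; beyond the scatter) that part of the change is expected to undo much of the loss. Among the measured compounds shown here, the entering 5-(pyridin-2-yl)thiophen-2-yl has no measured counterpart, so its own contribution is unknown and widens the range. The expected step for compound 4 is a 5.0-fold lower number from compound 3 to compound 4 (0.70 log units; beyond the scatter), landing near compound 2. Compound 4 is estimated at 8 nM, range 2.5 nM to 25 nM.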

Compound 4, inhibition constant: 2.51 nM
For compound 4 the middle estimate is 3.2-fold (0.50 log units) above the measured one; the measured number falls inside the stated range.
By their numbers in this assay, from the lowest: compound 4; then compounds 2 and 1 (each within the scatter of the next); then compound 3.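

In this assay, 5-(pyridin-2-yl)thiophen-2-yl replaces furan-2-yl with a 2.5-fold lower number from compound 2 to compound 4 (0.40 log units; beyond the scatter), so this position accepts a larger aromatic group with a gain, whereas the methylcarbamoyl on the furan gave a loss. Among these compounds, replacing the whole methylcarbamoyl-bearing group gives a 16-fold lower number from compound 3 to compound 4 (1.20 log units; beyond the scatter), the largest step so far. No evidence on hand accounts for either step.

On these data alone, whether the gain belongs to the thiophene or to the pyridine stays open. The plain thiophen-2-yl, or a phenyl in place of the pyridin-2-yl, would separate the two.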